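Changing the Aryl Group on a Shared Kinase Binder Core

This account rests on a few compounds, and the source may have more. Where it says the series, first, only, none or still open, it means among the compounds named here.

Compound 1 `CCCS(=O)(=O)Nc1ccc(F)c(C(=O)c2n[nH]c3ncc(-c4ccccc4C)cc23)c1F`: 7%
Compound 2 `CCCS(=O)(=O)Nc1ccc(F)c(C(=O)c2n[nH]c3ncc(-c4ccc(OC)cc4)cc23)c1F`: 4.2%
Compound 3 `CCCS(=O)(=O)Nc1ccc(F)c(C(=O)c2n[nH]c3ncc(-c4ccc(O)cc4)cc23)c1F`: 0.75%

These three compounds share one core and differ only in the aryl group attached to it. In an assay for binding affinity to dual specificity mitogen-activated protein kinase kinase 4 (Homo sapiens), read by KINOMEscan, tested at 100 nM (a lower number here means a stronger effect, a higher number a weaker effect of the compound at the concentration tested), compound 3 gives the lowest of the three numbers, yet the steps of a number 6.3 percentage points lower from compound 1 to compound 3 (within the scatter) and a number 3.5 percentage points lower from compound 2 to compound 3 (within the scatter) both lie within the scatter, so no ordering can be read from them. Compound 4 `CCCS(=O)(=O)Nc1ccc(F)c(C(=O)c2n[nH]c3ncc(-c4cc(Cl)cc(Cl)c4)cc23)c1F` carries 3,5-dichlorophenyl in place of 4-hydroxyphenyl on an aromatic carbon. For the measured compounds named here, no measured step involves a dichlorophenyl group; the three steps among compounds 1, 2 and 3, including a number 2.8 percentage points lower from compound 1 to compound 2 (within the scatter), all stayed within the scatter, so in this assay a change of a number 4.3 percentage points higher from compound 3 to compound 4 (within the scatter) is expected, that is none beyond the scatter. Compound 4 is therefore estimated at 5%, with a range from 0.5% to 20%.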

Compound 4, a percentage reported as activity, at one concentration (the size of the read-out at that concentration, not a potency): 73%
Beside the measured number, compound 4's estimate is 68 percentage points below it; measured number above the stated range.
By their numbers in this assay, from the lowest: compounds 3, 2 and 1 (each within the scatter of the next); then compound 4.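

In this assay, for the compounds shown here, this position proves sensitive to the choice of aryl group, which the earlier compounds did not show: the change to 3,5-dichlorophenyl gives a number 72.3 percentage points higher from compound 3 to compound 4 (beyond the scatter), a number 68.8 percentage points higher from compound 2 to compound 4 (beyond the scatter) and a number 66 percentage points higher from compound 1 to compound 4 (beyond the scatter). Each step points to a much weaker effect at the concentration tested, while the three earlier aryl groups remain within the scatter of one another. No available evidence explains this difference. Going by these compounds, it remains open whether one chlorine is enough, as in 3-chlorophenyl or 4-chlorophenyl, or whether both are needed. 3,5-Dimethylphenyl would show whether the result is specific to chlorine.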